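Branching the chain on compound 2

The source may report more compounds than this note shows. Statements on the series, on what has been measured and on what is new or still open speak of the compounds shown alone.

Among the compounds with values here, in a functional assay on the whole organism with Scenedesmus acutus as the target, with a stated time of 20 h (a lower number here means a stronger inhibitor, a higher number a weaker inhibitor), compound 2 (`CCCOC(=O)c1cc(N2C(=O)C3=C(CCCC3)C2=O)ccc1Cl`) gives 661 nM, the lowest of the two numbers so far. Compound 1 (`COC(=O)c1cc(N2C(=O)C3=C(CCCC3)C2=O)ccc1Cl`) gives 1620 nM, the nearest and only neighbour. Compound 3 (`CC(C)OC(=O)c1cc(N2C(=O)C3=C(CCCC3)C2=O)ccc1Cl`) keeps the shared core and has the same atoms as compound 2, joined differently: isopropyl in place of propyl on an oxygen next to a carbonyl group. Within the data shown here, one measured step bears on this, a 2.5-fold lower number from compound 1 to compound 2 (0.39 log units; beyond the scatter), modest and beyond the scatter, made on the same oxygen. Among the measured compounds shown here, that step changed the chain by adding atoms, so no measured pair tests branching, and its direction cannot simply be carried over. No step beyond the scatter is expected in this assay, with a slight lean towards a higher number. The estimated change is a 1.2-fold higher number from compound 2 to compound 3 (0.08 log units; within the scatter). For compound 3 the expected value is 800 nM, with an estimated range of 300 nM to 1900 nM.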

Compound 3, half-maximal inhibitory concentration: 182 nM
For compound 3 the middle estimate is 4.4-fold (0.64 log units) above the measured one, and the stated range ends above it.
By their numbers in this assay, from the lowest: compound 3; then compound 2; then compound 1.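

At the oxygen next to a carbonyl group, propyl and isopropyl share the same heavy-atom count but are not interchangeable in this assay, as the change of joining alone gives a 3.6-fold lower number from compound 2 to compound 3 (0.56 log units; beyond the scatter). Branching therefore counts at this place, and isopropyl gives the largest step on this oxygen among the compounds shown (an 8.9-fold lower number from compound 1 to compound 3 (0.95 log units; beyond the scatter)), compared with the straight propyl chain (a 2.5-fold lower number from compound 1 to compound 2 (0.39 log units; beyond the scatter)). No available data explain why the branched chain gives the lower number.

Three esters cannot show whether the trend continues with heavier branching, as in tert-butyl, or with a ring on the oxygen, as in cyclopentyl. Going by these compounds, whether a longer chain such as butyl, or an amide in place of the ester, would hold the number at the level of compound 3 also remains open.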